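The compounds below may be only part of what the source reports. "The series", "measured", "known", "first", "only" and "open" are said of these compounds alone.

Measured so far:
compound 1 `CC(C)=CCOc1cc(Nc2ncnc(Cl)n2)ccc1Cl`, 45000 nM
compound 2 `COc1ccnc(Nc2ccc(Cl)c(OCC=C(C)C)c2)n1`, 9000 nM
compound 3 `COCc1ccnc(Nc2ccc(Cl)c(OCC=C(C)C)c2)n1`, > 25000 nM

In an ADME assay on MT2 cells (Homo sapiens) for cytotoxicity (on this read-out higher numbers stand for lower toxicity in this test and lower numbers for higher toxicity in this test), compound 1 gives 45000 nM. Compound 2 gives 9000 nM in this assay. For compound 3 the assay reports only a limit, > 25000 nM, and not a number. Within the data shown here, the only measured step that bears on the change under study is an at least 2.7-fold higher number from compound 2 to compound 3 (0.44 log units; beyond the scatter); it shows that enlarging the group on that aromatic carbon raised the number beyond the scatter, though the size of the step is known only as a lower bound because compound 3 sits at the limit of > 25000 nM in this assay, at which 1 of the 3 values shown sits.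

Compound 4 `CC(C)=CCOc1cc(Nc2ncccn2)ccc1Cl` differs from compound 3 by hydrogen in place of methoxymethyl on an aromatic carbon. Among the measured compounds shown here, the data hold no measured pair in which this group is removed to leave a bare hydrogen at that position, so the single step from compound 2 to compound 3 is all that can be weighed. It concerns a change in the opposite direction, from a smaller to a larger group, and the unknown extent of the step leaves room on both sides.

Compound 4 is therefore expected to lie near the limit of compound 3, with a step that the limit leaves unreadable from compound 3 to compound 4 in this assay. The estimate for compound 4 in this assay is 30000 nM, within a range of 9000 nM to 100000 nM.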

Compound 4, half-maximal cytotoxic concentration: 2500 nM
The estimate for compound 4 lay 12-fold (1.08 log units) above the measured number; measured number below the stated range.
By their numbers in this assay, from the lowest: compound 4; then compound 2; then compound 1.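

In this assay, taking the group off this aromatic carbon lowered the number: hydrogen in place of methoxymethyl gives an at least 10-fold lower number from compound 3 to compound 4 (1.00 log units; beyond the scatter), and hydrogen in place of methoxy gives a 3.6-fold lower number from compound 2 to compound 4 (0.56 log units; beyond the scatter). Together with the earlier at least 2.7-fold higher number from compound 2 to compound 3 (0.44 log units; beyond the scatter), these steps put the three groups on that carbon in an order of rising number across compound 4, compound 2 and compound 3: hydrogen, then methoxy, then methoxymethyl. The bare ring is also far from the 4-chloro-1,3,5-triazin-2-yl group on the nitrogen, since pyrimidin-2-yl in its place gives an 18-fold lower number from compound 1 to compound 4 (1.26 log units; beyond the scatter), so compound 4 has the lowest number of those measured, and its step to each other compound is beyond the scatter.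

How far the number rises with methoxymethyl stays open, for compound 3 gives only a limit: the limit of > 25000 nM in this assay, at which 1 of the 4 values shown sits.

As far as these compounds go, whether an amine or a longer chain on that aromatic carbon would fit the same order is also open, as is whether the order holds with the 4-chloro-1,3,5-triazin-2-yl group on the nitrogen.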